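The compounds below may be only part of what the source reports. "The series", "measured", "known", "first", "only" and "open" are said of these compounds alone.

Compound 1 `O=C(/C=C/c1cccc(NC(=O)c2ccccc2Cl)c1)c1nc2ccccc2[nH]1` gives 3690 nM in a functional assay on 143B cells (Homo sapiens) for antiproliferative activity, read by MTT assay, with a stated time of 48 h; a lower number here means a stronger inhibitor, a higher number a weaker inhibitor.
Compound 2 `O=C(Nc1cccc(/C=C/C(=O)c2nc3ccccc3[nH]2)c1)c1cccc(Br)c1` gives 4620 nM in this assay.
Compound 3 `Cc1cccc(C(=O)Nc2cccc(/C=C/C(=O)c3nc4ccccc4[nH]3)c2)c1` gives 4880 nM in this assay.

Compound 3 shows the highest of the three numbers, yet its gaps to the others are small: a 1.1-fold higher number from compound 2 to compound 3 (0.02 log units; within the scatter) and a 1.3-fold higher number from compound 1 to compound 3 (0.12 log units; within the scatter), both within the scatter. Compound 4 `COc1ccc(C(=O)Nc2cccc(/C=C/C(=O)c3nc4ccccc4[nH]3)c2)cc1` differs from compound 3 by 4-methoxyphenyl in place of 3-methylphenyl on a carbonyl carbon. The measured steps that bear on this change are the earlier swaps of the ring on the same carbonyl carbon, a 1.3-fold higher number from compound 1 to compound 2 (0.10 log units; within the scatter) and a 1.3-fold higher number from compound 1 to compound 3 (0.12 log units; within the scatter), and the methyl-for-bromo step, a 1.1-fold higher number from compound 2 to compound 3 (0.02 log units; within the scatter); none of them left the scatter. Accordingly the expected step is a 1.1-fold lower number from compound 3 to compound 4 (0.04 log units; within the scatter), with no shift beyond the scatter. For compound 4 the estimate in this assay is 4500 nM, ranging from 2200 nM to 9000 nM.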

Compound 4, half-maximal inhibitory concentration: 6330 nM
Beside the measured number, compound 4's estimate is 1.4-fold (0.15 log units) below it; the range from low to high includes it.
By their numbers in this assay, from the lowest: compounds 1, 2, 3 and 4 (each within the scatter of the next).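

In this assay the 4-methoxyphenyl ring brings an oxygen to this carbonyl carbon for the first time among these compounds, yet a 1.3-fold higher number from compound 3 to compound 4 (0.11 log units; within the scatter) and a 1.4-fold higher number from compound 2 to compound 4 (0.14 log units; within the scatter) and a 1.7-fold higher number from compound 1 to compound 4 (0.23 log units; within the scatter) all lie within the scatter. Going by these compounds alone, the widest gap is now the one from the 2-chlorophenyl compound, and even that does not leave the scatter. So four differently substituted phenyl rings at this place cannot be told apart in this measurement.

As far as these compounds go, whether an amine or a carboxylic acid on this ring, or a longer chain in its place, would shift the number beyond the scatter remains open. No supporting data are available to explain why these rings read so alike.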